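Swapping the aryl group on a sulfonyl in a weak inhibitor series

The source may report more compounds than this note shows. Statements on the series, on what has been measured and on what is new or still open speak of the compounds shown alone.

Measured compounds:
compound 1, `COc1cc2nc(N3CCN(S(=O)(=O)c4ccc(Cl)cc4)CC3)nc(N)c2cc1OC`: 23000 nM
compound 2, `COc1cc2nc(N3CCN(S(=O)(=O)c4cccc([N+](=O)[O-])c4)CC3)nc(N)c2cc1OC`: 32000 nM

In a functional assay on PC-3 cells (Homo sapiens) for inhibition (a higher number here means a weaker inhibitor, a lower number a stronger inhibitor), compound 1 gives 23000 nM and compound 2 gives 32000 nM, so the two sit within the scatter of each other, as the step of a 1.4-fold higher number from compound 1 to compound 2 (0.14 log units; within the scatter) shows. Compound 3, `COc1ccc(S(=O)(=O)N2CCN(c3nc(N)c4cc(OC)c(OC)cc4n3)CC2)cc1`, has not yet been measured; it differs from compound 2 in one place: 4-methoxyphenyl in place of 3-nitrophenyl on a sulfonyl sulfur. Going by the values given here, the only comparable step, the aryl swap a 1.4-fold higher number from compound 1 to compound 2 (0.14 log units; within the scatter), stayed within the scatter, so for compound 3 a step of about a 1.3-fold lower number from compound 2 to compound 3 (0.11 log units; within the scatter) is expected, with no clear direction. Compound 3 is therefore estimated at 25000 nM, within a range of 10000 nM to 60000 nM.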

Compound 3, half-maximal inhibitory concentration: 39000 nM
Compound 3: middle estimate off by 1.6-fold (0.19 log units), on the low side; measured number inside the range.
By their numbers in this assay, from the lowest: compounds 1, 2 and 3 (each within the scatter of the next).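

Methoxy in place of chloro on an aromatic carbon gives a 1.7-fold higher number from compound 1 to compound 3 (0.23 log units; within the scatter) in this assay, and 4-methoxyphenyl in place of 3-nitrophenyl gives a 1.2-fold higher number from compound 2 to compound 3 (0.09 log units; within the scatter). A third aryl group on the sulfonyl sulfur therefore still leaves all three compounds within the scatter of one another. The data shown offer no measurement that could explain this.

From the compounds shown here alone, what an amine or a carboxylic acid on the aromatic ring would do stays open, as does a simple methyl in place of the whole aryl group. Going by these compounds, whether any group on this sulfonyl sulfur can give a clearly lower number also remains unknown.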